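The compounds below may be only part of what the source reports. "The series", "measured", "known", "first", "only" and "open" are said of these compounds alone.

Three compounds have been measured in a functional assay on HEK293 cells for agonist activity at G-protein coupled receptor 39 (Homo sapiens), read by scintillation proximity assay and inositol phosphate accumulation, with a stated time of 75 min; on this read-out higher numbers stand for an effect only at larger amounts of compound and lower numbers for an effect already at smaller amounts:

- compound 1 `Cc1nn(-c2ncnc3nc[nH]c23)c2c1C(OCc1ccc(Cl)cc1Cl)CC(=O)N2`: 243 nM
- compound 2 `Cc1nn(-c2ncnc3nc[nH]c23)c2c1C(OC1CCCC1)CC(=O)N2`: 62 nM
- compound 3 `COc1ccc(CCOC2CC(=O)Nc3c2c(C)nn3-c2ncnc3nc[nH]c23)cc1`: 70 nM

Compound 3 gives the second highest of the three numbers. Its nearest neighbour is compound 2, and the step of a 1.1-fold higher number from compound 2 to compound 3 (0.05 log units; within the scatter) lies within the scatter, so the two cannot be ordered. Its furthest neighbour is compound 1, and the step of a 3.5-fold lower number from compound 1 to compound 3 (0.54 log units; beyond the scatter) is a modest one beyond the scatter, as is the parallel step a 3.9-fold lower number from compound 1 to compound 2 (0.59 log units; beyond the scatter).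

Compound 4 `Cc1nn(-c2ncnc3nc[nH]c23)c2c1C(OCC(C)C)CC(=O)N2` has not yet been measured. It differs from compound 3 by isopropyl in place of 4-methoxybenzyl on a saturated chain carbon bound to an oxygen on a saturated carbon. For the measured compounds named here, the step that bears most directly on this change is the one from compound 2 to compound 3, where a cyclopentyl and a 2-(4-methoxyphenyl)ethyl on the same oxygen gave numbers within the scatter of each other. That suggests the part of the side chain beyond the oxygen tolerates an exchange of an aryl-containing chain for a small saturated group without a large shift. Going by the values given here, the isobutyl of compound 4 is smaller than the cyclopentyl of compound 2, and no measured step tells how far size alone may be reduced, so some widening of the range is warranted.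

Compound 4 is therefore expected to give 90 nM in this assay, with a range from 35 nM to 250 nM. This estimate means a step of a 1.3-fold higher number from compound 3 to compound 4 (0.11 log units; within the scatter), which is expected to stay within the scatter.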

Compound 4, half-maximal effective concentration: 111 nM
Compound 4: middle estimate off by 1.2-fold (0.09 log units), on the low side; low and high end bracket the measured number.
By their numbers in this assay, from the lowest: compounds 2, 3 and 4 (each within the scatter of the next); then compound 1.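

In this assay the side chain on this oxygen shrinks to isobutyl with no readable shift, as the exchange that removes the aromatic ring and the methoxy oxygen gives a 1.6-fold higher number from compound 3 to compound 4 (0.20 log units; within the scatter) and the exchange of cyclopentyl for isobutyl gives a 1.8-fold higher number from compound 2 to compound 4 (0.25 log units; within the scatter); compounds 2, 3 and 4 therefore cannot be ordered, and at this place neither a ring nor a chain as large as 2-(4-methoxyphenyl)ethyl is required for numbers in this range. Compound 1 goes against any simple link between size and the read-out, and the open-chain isobutyl also separates from its 2,4-dichlorobenzyl, with a 2.2-fold lower number from compound 1 to compound 4 (0.34 log units; beyond the scatter) as a modest step beyond the scatter, which leaves that group alone apart from the other three. Nothing independent of these numbers bears on why the side chains fall out this way.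

As far as these compounds go, whether a methyl or an ethyl on the same oxygen would hold the number, and so how far the chain can be shortened, remains open. Also open, from the compounds shown here alone, are whether an unsubstituted benzyl would match compound 1 or the other three, and what an amine or a carboxylic acid at the end of the chain would do.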